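The compounds below may be only part of what the source reports. "The series", "measured", "known", "first", "only" and "open" are said of these compounds alone.

Measured in an ADME assay on HEp-2 cells (Homo sapiens) for cytotoxicity, read by MTT assay, with a stated time of 72 h; on this read-out higher numbers stand for weaker inhibition and lower numbers for stronger inhibition:
Compound 1 `COc1ccc(C2=C(c3cc(OC)c(OC)c(OC)c3)C(=O)C(OC(C)=O)C2)cc1OC(C)C`: > 100 ug/mL (a limit)
Compound 2 `COc1ccc(C2=C(c3cc(OC)c(OC)c(OC)c3)C(=O)C(OC(C)=O)C2)cc1`: 18 ug/mL
Compound 3 `COc1ccc(C2=C(c3cc(OC)c(OC)c(OC)c3)C(=O)C(O)C2)cc1`: < 1 ug/mL (a limit)

Compound 2 gives 18 ug/mL. Among the measured compounds shown here, this is the only true number in the set, since the other two values are limits. Compound 4 `COc1ccc(C2=C(c3cc(OC)c(OC)c(OC)c3)C(=O)C(OC(C)=O)C2)cc1F` differs from it by fluoro in place of hydrogen on an aromatic carbon. The closest guide is the at least modest step an at least 5.5-fold lower number from compound 1 to compound 2 (0.74 log units; beyond the scatter), hydrogen in place of isopropoxy on an aromatic carbon. The large step of an at least 18-fold lower number from compound 2 to compound 3 (1.25 log units; beyond the scatter) concerns an acetyl on an oxygen, so it bears on this change only little. For the measured compounds named here, no measured step tests fluoro itself, and the change is small. The expected step is a 1.1-fold higher number from compound 2 to compound 4 (0.05 log units; within the scatter), which would lie within the scatter. For compound 4 the estimated value is 20 ug/mL, with an expected range of 6 ug/mL to 60 ug/mL.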

Compound 4, half-maximal inhibitory concentration: < 1 ug/mL
Compound 4: only a limit was reported; the forecaster's own chance of this, stated with the estimate: 15%; at least 20-fold (1.30 log units) between middle value and limit.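

In this assay, among the compounds shown here, the earlier compounds showed only that isopropoxy on this aromatic carbon goes with a higher number than hydrogen, whereas fluoro moves the read-out the other way, with an at least 18-fold lower number from compound 2 to compound 4 (1.25 log units; beyond the scatter) and an at least 100-fold lower number from compound 1 to compound 4 (2.00 log units; beyond the scatter). A single fluoro ortho to a methoxy group therefore matters greatly here, even with the acetyl on the oxygen kept. The value of compound 4 is a limit, < 1 ug/mL, so the full size of both steps stays unknown: the limit of < 1 ug/mL in this assay, at which 2 of the 4 values shown sit.

From the compounds shown here alone, whether chloro, hydroxyl or an amine at this place would act like fluoro remains open. So does what fluoro would do alongside the free hydroxyl of compound 3.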